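A few compounds are considered here, and "the series" means these few. Any claim that something is new, unique, unknown or untested is made for them only; others in the source may bear on it.

Among the measured compounds shown here, in a functional assay on MDA-MB-435 cells (Homo sapiens) for cytotoxicity, read by MTT assay, with a stated time of 72 h (a lower number here means a stronger inhibitor, a higher number a weaker inhibitor), compound 1 (`Nc1cccc(Nc2c(C(=O)NCc3ccc(F)cc3)nc(Br)c3cccnc23)c1`) gives 8000 nM and compound 2 (`N[C@H]1CC[C@H](Nc2c(C(=O)NCc3ccc(F)cc3)nc(Br)c3cccnc23)CC1`) gives 6000 nM as the only numbers so far. For the measured compounds named here, the two stand level: the only measured step (a 1.3-fold lower number from compound 1 to compound 2 (0.12 log units; within the scatter)) puts 4-aminocyclohexyl in place of 3-aminophenyl on a nitrogen on an aromatic ring. Compound 3 (`N[C@H]1CC[C@H](Nc2c(C(=O)NCc3ccc(Cl)cc3)nc(Br)c3cccnc23)CC1`) differs from compound 2 at one place only (chloro in place of fluoro on an aromatic carbon) with chloro in place of fluoro on an aromatic carbon, para to a large group. Going by the values given here, no measured step touches this halogen, so the one step in hand lends no size to carry over. The expectation rests on compound 2 at 6000 nM as its anchor, and no shift beyond the scatter is expected in this assay in either direction. The estimated step (a 1.2-fold lower number from compound 2 to compound 3 (0.08 log units; within the scatter)) is expected to be small. Compound 3 is expected near 5000 nM within an estimated range from 2500 nM to 10000 nM in this measurement.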

Compound 3, half-maximal inhibitory concentration: 1000 nM
Compound 3: middle estimate off by 5.0-fold (0.70 log units), on the high side, outside the stated range (below it).
By their numbers in this assay, from the lowest: compound 3; then compounds 2 and 1 (each within the scatter of the next).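

In this assay, the change from 4-fluorobenzyl to 4-chlorobenzyl gives a 6.0-fold lower number from compound 2 to compound 3 (0.78 log units; beyond the scatter), whereas the earlier exchange of 3-aminophenyl for 4-aminocyclohexyl gave only a 1.3-fold lower number from compound 1 to compound 2 (0.12 log units; within the scatter). This place on the six-membered aromatic ring, para to a large group, therefore responds to the exchange of a single halogen atom, even though the counts of hydrogen-bond donors and acceptors and the net charge stay the same. No evidence in hand bears on the reason for this step.

Going by these compounds, it remains open whether a bromine, a methyl or a methoxy group at this place would give a number nearer that of compound 3 or that of compound 2. On these data alone, it is also open whether chloro in place of fluoro would give a similar step on the 3-aminophenyl compound.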